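This account rests on a few compounds, and the source may have more. Where it says the series, first, only, none or still open, it means among the compounds named here.

Measured so far in a functional assay on MCF7 cells (Homo sapiens) for inhibition, read by MTT assay, with a stated time of 72 h; a lower number here means a stronger inhibitor, a higher number a weaker inhibitor:
- Compound 1 `CCCc1ccc(NC(=O)C2CCN(C/C=C/c3ccccc3)CC2)cc1`: 9030 nM
- Compound 2 `COc1cccc(NC(=O)C2CCN(C/C=C/c3ccccc3)CC2)c1`: 42700 nM
- Compound 3 `O=C(Nc1cccc(F)c1)C1CCN(C/C=C/c2ccccc2)CC1`: 33000 nM

Compound 3 cannot be told apart from compound 2, as the comparison shows: a 1.3-fold lower number from compound 2 to compound 3 (0.11 log units; within the scatter). Compound 1 holds the lowest number of the three, and the gap to it is real: a 3.7-fold higher number from compound 1 to compound 3 (0.56 log units; beyond the scatter).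

Compound 4 `O=C(Nc1ccccn1)C1CCN(C/C=C/c2ccccc2)CC1` changes one group of compound 3: pyridin-2-yl in place of 3-fluorophenyl on an amide-type nitrogen. In words, pyridin-2-yl takes the place of 3-fluorophenyl on an amide-type nitrogen.

Two measured steps changed this same group, a 4.7-fold higher number from compound 1 to compound 2 (0.67 log units; beyond the scatter) and a 3.7-fold higher number from compound 1 to compound 3 (0.56 log units; beyond the scatter), and both were modest. Among the measured compounds shown here, no measured compound carries pyridin-2-yl, so the direction remains uncertain. Compound 4 lacks the 4-propylphenyl of compound 1 at 9030 nM, so it is expected to stay close to compound 3 rather than approach compound 1.

The expected change is small, an estimated 1.3-fold higher number from compound 3 to compound 4 (0.10 log units; within the scatter). For compound 4 the estimated value is 42000 nM, with an expected range from 17000 nM to 100000 nM.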

Compound 4, half-maximal inhibitory concentration: 67200 nM
Estimate against measurement, compound 4: 1.6-fold (0.20 log units) below; low and high end bracket the measured number.
By their numbers in this assay, from the lowest: compound 1; then compounds 3, 2 and 4 (each within the scatter of the next, the first and the last beyond it).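

In this assay, among the compounds shown here, the amide-type nitrogen now carries a ring with a hetero atom for the first time, and pyridin-2-yl brings no gain here: a 2.0-fold higher number from compound 3 to compound 4 (0.31 log units; beyond the scatter) is a modest move towards weaker inhibition, while a 1.6-fold higher number from compound 2 to compound 4 (0.20 log units; within the scatter) stays within the scatter. The widest gap at this position so far is a 7.4-fold higher number from compound 1 to compound 4 (0.87 log units; beyond the scatter) and adds to the picture that all three replacements of 4-propylphenyl shown give higher numbers than compound 1. Nothing available explains this result.

The compounds shown leave open whether the propyl chain itself accounts for the lower number of compound 1, which a butyl chain or a shorter ethyl chain on the same ring could test. They also leave open whether a pyridine ring carrying a propyl chain would recover what pyridin-2-yl lacks.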